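Compound 3: One More Acyl Change at the Limit

The source may hold more compounds than are shown below. What is called first, only, known or untested is meant among the compounds shown, and "the series" means these compounds.

Measured so far in an ADME assay on BaF3 cells (Mus musculus) for cytotoxicity, read by CellTiter-Glo and CCK-8 assay, with a stated time of 72 h (a higher number here means a weaker inhibitor of growth, a lower number a stronger inhibitor of growth), both values being limits:
- compound 1 (`CCCC(=O)N(CCN(C)C)Cc1ccc(C(=O)Nc2ccc(C)c(Nc3nccc(-c4cccnc4)n3)c2)cc1`) with > 10000 nM as its limit
- compound 2 (`Cc1ccc(NC(=O)c2ccc(CN(CCN(C)C)C(=O)C(C)(C)C)cc2)cc1Nc1nccc(-c2cccnc2)n1`) with > 10000 nM as its limit

Compound 2 gives no number, only the limit > 10000 nM in this series. The whole record so far is the limit of > 10000 nM in this assay, at which 2 of the 2 values shown sit, and nothing more.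

Compound 3 (`Cc1ccc(NC(=O)c2ccc(CN(CCN(C)C)C(=O)c3cccs3)cc2)cc1Nc1nccc(-c2cccnc2)n1`) has thiophen-2-yl in place of tert-butyl on a carbonyl carbon, so a five-membered aromatic ring with 1 hetero atom enters where no ring stood before.

Within the data shown here, only one measured step bears on this carbonyl carbon, where tert-butyl took the place of propyl. That step, a step that the two limits leave unreadable from compound 1 to compound 2, offers no size and no direction to carry over. No step beyond the scatter is therefore expected in this assay, and a further limit is the likeliest report.

The expected step is a number no higher from compound 2 to compound 3 (the limit leaves the size open) at most a small one. For compound 3 the estimated value is 10000 nM, with an expected range from 3000 nM to 30000 nM in all.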

Compound 3, concentration for 50% growth inhibition: > 10000 nM
Compound 3 gave a limit, no number; the forecaster's own chance of this, stated with the estimate: 75%; the middle value sits exactly at the limit.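

No step among compound 1, compound 2 and compound 3 can be read in this assay, because all three give only a limit and no number: the limit of > 10000 nM in this assay, at which 3 of the 3 values shown sit.

The compounds shown leave open whether propyl, tert-butyl and thiophen-2-yl on the carbonyl carbon differ at all in this assay, and what number any of the three would reach.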